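The source may report more compounds than this note shows. Statements on the series, on what has been measured and on what is new or still open speak of the compounds shown alone.

Measured so far:
- compound 1 `CNC(=O)c1ccncc1Nc1cc(-c2ccc3ccn(C)c3c2)c2nccnc2c1`: 7020 nM
- compound 2 `CN(C)C(=O)c1ccncc1Nc1cc(-c2ccc3ccn(C)c3c2)c2nccnc2c1`: > 100000 nM
- compound 3 `Cn1ccc2ccc(-c3cc(Nc4cnccc4C(=O)NCc4cncnc4)cc4nccnc34)cc21`: 49500 nM

In an assay on lysate for inhibition of 6-phosphofructo-2-kinase/fructose-2,6-bisphosphatase 3 (Homo sapiens), with stated times of 0.5 min and 45 min (a lower number here means a stronger inhibitor, a higher number a weaker inhibitor), compound 3 gives the highest of the two numbers reported. Its nearest neighbour is compound 1, and the step from one to the other is a 7.1-fold higher number from compound 1 to compound 3 (0.85 log units; beyond the scatter). Compound 2 is not a number but a limit of this assay, (the limit of > 100000 nM in this assay, at which 1 of the 3 values shown sits). Compound 4 `Cn1cc(NC(=O)c2ccncc2Nc2cc(-c3ccc4ccn(C)c4c3)c3nccnc3c2)cn1` has not yet been measured; it differs from compound 3 in that (1-methyl-1H-pyrazol-4-yl in place of (pyrimidin-5-yl)methyl on an amide-type nitrogen). For the measured compounds named here, two measured steps touch the same amide-type nitrogen: an at least 14-fold higher number from compound 1 to compound 2 (1.15 log units; beyond the scatter) and a 7.1-fold higher number from compound 1 to compound 3 (0.85 log units; beyond the scatter), both weakening, while an at least 2.0-fold lower number from compound 2 to compound 3 (0.30 log units; that floor lies within the scatter) stays within the scatter. None of them swaps one substituent on that nitrogen for another of similar size, so the direction of the new step is not fixed by what is shown. Compound 4 is therefore expected to stay near compound 3, with a 1.7-fold lower number from compound 3 to compound 4 (0.22 log units; within the scatter) as the estimated step. The estimate for compound 4 in this assay is 30000 nM, within 8000 nM to 120000 nM.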

Compound 4, half-maximal inhibitory concentration: 26500 nM
Estimate against measurement, compound 4: 1.1-fold (0.05 log units) above; the measured number falls inside the stated range.
By their numbers in this assay, from the lowest: compound 1; then compounds 4 and 3 (each within the scatter of the next). At a limit, above all of these: compound 2.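

In this assay, a directly attached 1-methyl-1H-pyrazol-4-yl and a (pyrimidin-5-yl)methyl on the amide-type nitrogen cannot be told apart, with a 1.9-fold lower number from compound 3 to compound 4 (0.27 log units; within the scatter). The methyl of compound 1 nonetheless remains ahead of this new group, with a 3.8-fold higher number from compound 1 to compound 4 (0.58 log units; beyond the scatter), so neither ring-bearing substituent shown on that nitrogen matches it. Compound 2 is only a limit of the assay and not a number, yet with (1-methyl-1H-pyrazol-4-yl)amino in place of its dimethylamino on the carbonyl carbon the reading is an at least 3.7-fold lower number from compound 2 to compound 4 (0.57 log units; beyond the scatter).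

The compounds shown leave open whether an ethyl or cyclopropyl on that nitrogen would hold or improve on the number of compound 1. They also leave open whether a 2-hydroxyethyl chain or a pyrazol-4-yl without its methyl would differ from compound 4.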